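Chloro to Fluoro: Estimating Compound 4

The source may hold more compounds than are shown below. What is called first, only, known or untested is meant among the compounds shown, and "the series" means these compounds.

Measured in a functional assay on A549 cells (Homo sapiens) for cytotoxicity, read by MTT assay, with a stated time of 48 h; a higher number here means a weaker inhibitor, a lower number a stronger inhibitor:
- Compound 1 `CCOC(=O)c1c(-c2cc3ccccc3oc2=O)nn(-c2ccccc2)c1C(=O)OCC` gives 100000 nM
- Compound 2 `CCOC(=O)c1c(-c2cc3ccccc3oc2=O)nn(-c2ccc(OC)cc2)c1C(=O)OCC` gives 86000 nM
- Compound 3 `CCOC(=O)c1c(-c2cc3ccccc3oc2=O)nn(-c2cccc(Cl)c2)c1C(=O)OCC` gives 28000 nM

Compound 3 has the lowest number of the three. Its distance from compound 2 is a 3.1-fold lower number from compound 2 to compound 3 (0.49 log units; beyond the scatter), and from compound 1 it is a 3.6-fold lower number from compound 1 to compound 3 (0.55 log units; beyond the scatter); both steps lie beyond the scatter, so compound 3 is the strongest inhibitor here. Compound 1 and compound 2 differ only by a 1.2-fold lower number from compound 1 to compound 2 (0.07 log units; within the scatter), which is within the scatter, so no order can be read between them.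

Compound 4 `CCOC(=O)c1c(-c2cc3ccccc3oc2=O)nn(-c2cccc(F)c2)c1C(=O)OCC` is the next structure, and it differs from compound 3 as follows: fluoro in place of chloro on an aromatic carbon.

For the measured compounds named here, the step that bears on this is the one from compound 1 to compound 3, where chloro entered in place of hydrogen and the number fell modestly, a 3.6-fold lower number from compound 1 to compound 3 (0.55 log units; beyond the scatter). Going by the values given here, no measured step shows fluoro at this position, so the size of the effect of fluoro is unknown; a value between that of compound 1 and compound 3 seems most likely, that is a rise in number from compound 3 of modest size.

Compound 4 is therefore expected to give 50000 nM in this assay, within a range of 22000 nM to 110000 nM, meaning an expected step of a 1.8-fold higher number from compound 3 to compound 4 (0.25 log units; within the scatter).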

Compound 4, half-maximal inhibitory concentration: 59000 nM
Compound 4: the middle estimate sits 1.2-fold (0.07 log units) below what was measured; the measured number falls inside the stated range.
By their numbers in this assay, from the lowest: compound 3; then compounds 4, 2 and 1 (each within the scatter of the next).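

In this assay the change from chloro to fluoro replaces a single atom on the aromatic carbon meta to a large group, and it still gives a 2.1-fold higher number from compound 3 to compound 4 (0.32 log units; beyond the scatter) so the two halogens are not interchangeable at this position. Fluoro in place of hydrogen gives only a 1.7-fold lower number from compound 1 to compound 4 (0.23 log units; within the scatter) and 3-fluorophenyl in place of 4-methoxyphenyl gives a 1.5-fold lower number from compound 2 to compound 4 (0.16 log units; within the scatter) so neither step supports an order, and of the two halogens only chloro stands apart from hydrogen by a step beyond the scatter. No measurement offered here explains why chloro and fluoro differ at this position.

The compounds shown leave open whether a bromo or trifluoromethyl group on the same carbon would give a number nearer to that of the chloro compound or to that of the fluoro compound. They also leave open whether chloro would give a similar step on another carbon of the ring, and how the numbers would respond if a carboxylic acid or an amide replaced the ethyl esters on the shared core.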